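A few compounds are considered here, and "the series" means these few. Any claim that something is new, unique, unknown or untested is made for them only; others in the source may bear on it.

Working notes on the series:
- compound 1 `CCCC(=O)CC/C=C/C=C/C#CC#C/C=C/COC(C)=O`: 21600 nM
- compound 2 `CCCC(=O)CC/C=C/C=C/C#CC#C/C=C/COC(=O)c1ccccc1`: > 30000 nM

In a functional assay on MCF7 cells (Homo sapiens) for cytotoxicity, read by sulforhodamine B assay, with a stated time of 96 h (on this read-out higher numbers stand for an effect only at larger amounts of compound and lower numbers for an effect already at smaller amounts), compound 2 stands at > 30000 nM, which is a limit of the assay and not a number. Compound 3 `CCCC(=O)CC/C=C/C=C/C#CC#C/C=C/COC(=O)CCl` has not been measured yet. It carries chloromethyl in place of phenyl on a carbonyl carbon. Within the data shown here, one measured step bears on this place, the reverse kind of exchange on the same carbonyl carbon: an at least 1.3-fold higher number from compound 1 to compound 2 (0.14 log units; that floor lies within the scatter). That step stays within the scatter, so it sets no firm size. With phenyl gone, compound 3 is expected to read near compound 1 at 21600 nM, and no large step is expected. The expected change is an at least 2.0-fold lower number from compound 2 to compound 3 (0.30 log units; that floor lies within the scatter), towards a lower number. The estimate for compound 3 is 15000 nM, with an expected range from 5000 nM to 35000 nM.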

Compound 3, half-maximal effective concentration: 26900 nM
For compound 3 the middle estimate is 1.8-fold (0.25 log units) below the measured one; measured number inside the range.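

In this assay, chloromethyl in place of phenyl on a carbonyl carbon gives an at least 1.1-fold lower number from compound 2 to compound 3 (0.04 log units; that floor lies within the scatter), a floor and not a measured size. Compound 2 carries a limit of the assay and not a number: the limit of > 30000 nM in this assay, at which 1 of the 3 values shown sits. Chloro in place of hydrogen on a saturated chain carbon bound to a carbonyl carbon gives a 1.2-fold higher number from compound 1 to compound 3 (0.10 log units; within the scatter), so compound 1 and compound 3 read alike on this read-out and this exchange sets no measurable step at this position.

From the compounds shown here alone, the true size of the step between phenyl and chloromethyl stays open, as does whether any group on this carbonyl carbon can move the number beyond the scatter. An amine or a carboxylic acid on the saturated chain carbon, or a longer chain in place of its methyl, could test that.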